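The compounds below may be only part of what the source reports. "The series", "measured", "known", "first", "only" and "open" are said of these compounds alone.

Measured in a functional assay on MCF7 cells (Homo sapiens) for cytotoxicity, read by MTT assay, with a stated time of 72 h; a higher number here means a weaker inhibitor, a lower number a stronger inhibitor:

Compound 1 `Cc1cc(/C=C/c2ccc(O)c(O)c2)on1`: 6300 nM
Compound 2 `COc1ccc(/C=C/c2cc(C)no2)cc1`: > 100000 nM

Among the measured compounds shown here, only two compounds have been tested so far in this assay, and they do not carry the same kind of information. Compound 1 gives a true number, 6300 nM. For compound 2 the result is only a limit, > 100000 nM, and not a number.

The next compound, compound 3 `Cc1cc(/C=C/c2ccc(O)cc2)on1`, comes from compound 2 by a single change: hydrogen in place of methyl on an oxygen on an aromatic ring. This puts hydrogen in place of methyl on an oxygen on an aromatic ring, turning methoxy to hydroxy.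

A move towards stronger inhibition is expected, since compound 1, which also carries hydroxy on its aromatic ring, gives 6300 nM. Its size is uncertain, and a result that again reaches the limit of this assay remains possible. The expected step is an at least 3.3-fold lower number from compound 2 to compound 3 (0.52 log units; beyond the scatter), a modest one beyond the scatter. For compound 3 the estimated value is 30000 nM, with an expected range of 10000 nM to 100000 nM.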

Compound 3, half-maximal inhibitory concentration: 50200 nM
Compound 3: the middle estimate sits 1.7-fold (0.22 log units) below what was measured, within the range that was stated.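

In this assay, hydroxy in place of methoxy on the aromatic ring gives a true number where there had been only a limit, and the change reads as an at least 1.9-fold lower number from compound 2 to compound 3 (0.29 log units; that floor lies within the scatter). The full size of this step cannot be read, and its floor does not by itself establish a change beyond the scatter, because compound 2 is recorded only as a limit: the limit of > 100000 nM in this assay, at which 1 of the 3 values shown sits. The other step has true numbers at both ends and is therefore the first whose size can be read in full: hydrogen in place of hydroxy on an aromatic carbon gives an 8.0-fold higher number from compound 1 to compound 3 (0.90 log units; beyond the scatter), so the additional hydroxy of compound 1 goes with clearly stronger inhibition in this pair.

The compounds shown leave open whether the gain depends on hydroxy itself, since no other group appears at either place, and an amine or a fluorine there could separate the two possibilities. They also leave open how much the methyl on the shared core contributes, which a longer chain or a carboxylic acid at that place could begin to show.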